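The source may report more compounds than this note shows. Statements on the series, on what has been measured and on what is new or still open speak of the compounds shown alone.

Compound 1 `O=c1cc(CSC(=S)N2CCCC2)oc2ccccc12` carries a pyrrolidin-1-yl group on a thiocarbonyl carbon whose other neighbours are sulfur. In a functional assay on LM7 cells (Homo sapiens) for antiproliferative activity, read by MTT assay, with a stated time of 72 h (a higher number here means a weaker inhibitor, a lower number a stronger inhibitor), compound 1 gives 40000 nM. Compound 2 `O=c1cc(CSC(=S)N2CCCCC2)oc2ccccc12` differs from compound 1 by piperidin-1-yl in place of pyrrolidin-1-yl on a thiocarbonyl carbon. For compound 2 this assay reports only a limit, > 25000 nM, not a number. Because of the limit of > 25000 nM in this assay, at which 1 of the 3 values shown sits, the step that the limit leaves unreadable from compound 1 to compound 2 cannot be read as a size. Compound 3 `CCOC(=O)c1cc(=O)c2cc(CSC(=S)N3CCCC3)ccc2o1` rests on a different core; how the two cores differ is not broken down here. In this assay compound 3 gives 18000 nM, the lowest number among the measured compounds and beyond the usual scatter from compound 1. Compound 4 `CCOC(=O)c1cc(=O)c2cc(CSC(=S)N3CCCCC3)ccc2o1`, not yet measured, differs from compound 3 by piperidin-1-yl in place of pyrrolidin-1-yl on a thiocarbonyl carbon, the same change made at the same place as between compound 1 and compound 2. On these data alone, since a step that the limit leaves unreadable from compound 1 to compound 2 ends at a limit, its size is unknown, so the expectation for compound 4 rests mainly on compound 3 with its 18000 nM. The step of a 1.4-fold higher number from compound 3 to compound 4 (0.14 log units; within the scatter) is expected to be small. Compound 4 is therefore estimated at 25000 nM, between 10000 nM and 60000 nM.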

Compound 4, half-maximal inhibitory concentration: 16900 nM
For compound 4 the middle estimate is 1.5-fold (0.17 log units) above the measured one; measured number inside the range.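

In this assay, putting piperidin-1-yl in place of pyrrolidin-1-yl on a thiocarbonyl carbon gives a 1.1-fold lower number from compound 3 to compound 4 (0.03 log units; within the scatter), so on this core the swap of a five-membered for a six-membered ring leaves no readable change. The same swap on the core of compound 1 ends at compound 2, for which only a limit is reported, so that step cannot be read as a size: the limit of > 25000 nM in this assay, at which 1 of the 4 values shown sits. This leaves a single readable instance of the change, which shows what it does on one core but cannot show whether the result carries over to the other core, or differs there.

The compounds shown leave open whether other amines on the thiocarbonyl carbon, such as morpholine or diethylamine, would give a step beyond the scatter on either core. They also leave open what a carboxylic acid in place of the ethyl ester would do to the number.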